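Aminothiophene ketones: chloro for trifluoromethyl on the aryl ring

The source may report more compounds than this note shows. Statements on the series, on what has been measured and on what is new or still open speak of the compounds shown alone.

Measured so far:
compound 1 `Nc1scc(-c2cccc(C(F)(F)F)c2)c1C(=O)c1ccccc1` — 83%
compound 2 `Nc1scc(-c2ccccc2)c1C(=O)c1ccccc1` — 49%
compound 3 `Nc1scc(-c2ccc(F)cc2)c1C(=O)c1ccccc1` — 51%

In a functional assay on CHO cells for agonist activity at adenosine receptor A1 (Homo sapiens), read by fluorescence and ERK phosphorylation, with stated times of 30 min and 1.5 h, tested at 3 uM (a higher number here means a stronger effect of the compound at the concentration tested, a lower number a weaker effect), compound 1 gives the highest of the three numbers; its steps to both others lie beyond the scatter, a number 34 percentage points lower from compound 1 to compound 2 (beyond the scatter) being the larger, and compound 3 sits nearer but still well below it. The step of a number 2 percentage points higher from compound 2 to compound 3 (within the scatter) stays within the scatter, so among the measured compounds only the trifluoromethyl group has moved this assay.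

Compound 4 `Nc1scc(-c2cccc(Cl)c2)c1C(=O)c1ccccc1` is not yet measured. It differs from compound 1 in one place: chloro in place of trifluoromethyl on an aromatic carbon. Among the measured compounds shown here, the only step bearing on this is the removal of the trifluoromethyl group, which cost a number 34 percentage points lower from compound 1 to compound 2 (beyond the scatter); no step shows a chloro group anywhere in this set, so how much of that loss a single chlorine recovers is open. A step of moderate size downward in this assay is therefore expected, a number 15 percentage points lower from compound 1 to compound 4 (beyond the scatter), smaller than the drop to compound 2. Compound 4 is estimated at 68%, with a range from 50% to 85%.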

Compound 4, a percentage reported as activity, at one concentration (the size of the read-out at that concentration, not a potency): 45%
For compound 4 the middle estimate is 23 percentage points above the measured one; measured number below the stated range.
By their numbers in this assay, from the lowest: compounds 4, 2 and 3 (each within the scatter of the next); then compound 1.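

In this assay, chloro on this aromatic carbon does not take the place of trifluoromethyl: the result is a number 38 percentage points lower from compound 1 to compound 4 (beyond the scatter). Chloro also stands apart from neither of the other two compounds, with a number 4 percentage points lower from compound 2 to compound 4 (within the scatter) and a number 6 percentage points lower from compound 3 to compound 4 (within the scatter), so the high number of compound 1 stays tied to trifluoromethyl alone among the groups shown, and a halogen on this ring is not enough to reach it. Nothing at hand explains the gap between chloro and trifluoromethyl.

From the compounds shown here alone, whether a methyl, a methoxy or a nitrile on the same aromatic carbon would stand with compound 1 or with compound 4 remains open. These numbers give the size of the read-out at a single concentration, so the potency of these compounds is also open.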